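Replacing bromo with 2-hydroxyphenyl in compound 1

The source may hold more compounds than are shown below. What is called first, only, known or untested is meant among the compounds shown, and "the series" means these compounds.

In a functional assay on HCT-116 cells (Homo sapiens) for inhibition, with a stated time of 72 h (on this read-out lower numbers stand for stronger inhibition and higher numbers for weaker inhibition), compound 1 `NC1CCC(Nc2nc(NCc3ccc(Br)cc3)c3ncn(C4CCCC4)c3n2)CC1` gives 790 nM, the middle of three measured numbers. Compound 3 `NC1CCC(Nc2nc(NCc3ccc(-c4cccc(F)c4)nc3)c3ncn(C4CCCC4)c3n2)CC1` stands lower at 74 nM, while compound 2 `CC(C)(O)CNc1nc(NCc2ccc(-c3ccco3)cc2)c2ncn(C3CCCC3)c2n1` stands higher at 16700 nM, and both gaps to compound 1 lie beyond the scatter.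

Compound 4 `NC1CCC(Nc2nc(NCc3ccc(-c4ccccc4O)cc3)c3ncn(C4CCCC4)c3n2)CC1` has not yet been measured. It has 2-hydroxyphenyl in place of bromo on an aromatic carbon, para to a large group: 2-hydroxyphenyl in place of bromo on an aromatic carbon. Among the measured compounds shown here, no measured pair isolates this kind of change, so the evidence is indirect. Compound 3, which also carries an extra aromatic ring, gives 74 nM and points towards a lower number. Compound 2 goes against that reading, with an extra aromatic ring and 16700 nM, although it also differs from compound 1 elsewhere.

A moderate fall in this assay, probably beyond the scatter, is therefore expected, an estimated 4.6-fold lower number from compound 1 to compound 4 (0.67 log units; beyond the scatter). For compound 4 the estimated value is 170 nM, with an expected range from 40 nM to 700 nM.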

Compound 4, half-maximal inhibitory concentration: 4350 nM
Compound 4: middle estimate off by 26-fold (1.41 log units), on the low side, and the stated range ends below it.
By their numbers in this assay, from the lowest: compound 3; then compound 1; then compound 4; then compound 2.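

Among the compounds shown here, this is the first pair in the set that differs in one place only, and in this assay 2-hydroxyphenyl in place of bromo gives a 5.5-fold higher number from compound 1 to compound 4 (0.74 log units; beyond the scatter). At this aromatic carbon, para to a large group, the added six-membered aromatic ring with its hydroxy group therefore does not bring a lower number, and of the two groups bromo gives the lower one. Nothing among the data shown accounts for this rise.

Still open, from the compounds shown here alone, is whether the rise belongs to the added ring itself or to the hydroxy group it carries, a question that a plain phenyl group or a 2-methoxyphenyl group at this place would help to separate. Also open, going by these compounds, is whether a smaller group, such as chloro or an amine, would keep the number of compound 1 or shift it.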